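The source may report more compounds than this note shows. Statements on the series, on what has been measured and on what is new or still open speak of the compounds shown alone.

In a functional assay on HCT-116 cells (Homo sapiens) for antiproliferative activity, read by sulforhodamine B assay, with a stated time of 72 h (a lower number here means a stronger inhibitor, a higher number a weaker inhibitor), three compounds have been measured:

- compound 1 `COc1ncc(-c2ccc3ncnc(Nc4cnn(CCC(=O)O)c4)c3c2)cc1NS(C)(=O)=O`: 1290 nM
- compound 2 `CCCCS(=O)(=O)Nc1cc(-c2ccc3ncnc(Nc4ccc(OCCO)nc4)c3c2)cnc1OC`: > 20000 nM
- compound 3 `COc1ncc(-c2ccc3ncnc(Nc4ccc(OCCO)c(F)c4)c3c2)cc1NS(=O)(=O)c1ccc(F)cc1F`: 9160 nM

Compound 2 is the only one of the three without a number. From the compounds shown here alone, its reading of > 20000 nM is a limit of the assay and not a measured potency, so its true place on the scale remains open.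

Compound 4 `COc1ncc(-c2ccc3ncnc(Nc4ccc(OCCO)nc4)c3c2)cc1NS(C)(=O)=O` departs from compound 2 in one place: hydrogen in place of propyl on a saturated chain carbon bound to a sulfonyl sulfur. In words, hydrogen takes the place of propyl on a saturated chain carbon bound to a sulfonyl sulfur, which turns butylsulfonyl into methylsulfonyl.

For the measured compounds named here, no measured pair shows this change directly in this assay, so the expectation rests on thin ground. Compound 1 also carries the methanesulfonamido group and gives 1290 nM, which points towards stronger inhibition. The expected step is therefore towards a lower number and beyond the usual scatter: an at least 4.0-fold lower number from compound 2 to compound 4 (0.60 log units; beyond the scatter). For compound 4 the estimated value is 5000 nM, with an expected range of 1500 nM to 18000 nM.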

Compound 4, half-maximal inhibitory concentration: 5360 nM
For compound 4 the middle estimate is 1.1-fold (0.03 log units) below the measured one, and the stated range covers the measured number.
By their numbers in this assay, from the lowest: compound 1; then compounds 4 and 3 (each within the scatter of the next). At a limit, above all of these: compound 2.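

In this assay, turning butylsulfonyl into methylsulfonyl takes the compound from a limit to a measured number, with an at least 3.7-fold lower number from compound 2 to compound 4 (0.57 log units; beyond the scatter). That step sets only a lower bound on the size of the change, since compound 2 has no measured number: the limit of > 20000 nM in this assay, at which 1 of the 4 values shown sits. With the methanesulfonamido group held fixed, the group on the nitrogen on an aromatic ring also matters: 6-(2-hydroxyethoxy)pyridin-3-yl in place of 1-(2-carboxyethyl)-1H-pyrazol-4-yl goes with a 4.2-fold higher number from compound 1 to compound 4 (0.62 log units; beyond the scatter).

The compounds shown leave open where an ethyl chain on the sulfonyl would fall, and whether the number follows chain length at all. They also leave open whether an amine in place of the carboxylic acid of compound 1 would keep its number.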